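Swapping Cyano for Methoxy on the Aryl Ring

The compounds below may be only part of what the source reports. "The series", "measured", "known", "first", "only" and "open" are said of these compounds alone.

Of the compounds shown here, three sharing one core have been measured in a functional assay on SGC-7901 cells (Homo sapiens) for inhibition, read by MTT assay, with a stated time of 24 h; a lower number here means a stronger inhibitor, a higher number a weaker inhibitor. Compound 1 `CC1(C)[C@H]2CC[C@]1(C)N(Cc1cn(-c3ccc(C#N)cc3)nn1)C(=O)C2` gives 500 nM, the highest of the three numbers, though each gap to it lies within the scatter. Compound 2 `CC1(C)[C@H]2CC[C@]1(C)N(Cc1cn(-c3cccc(O)c3)nn1)C(=O)C2` gives 270 nM, and compound 3 `Cc1ccccc1-n1cc(CN2C(=O)C[C@@H]3CC[C@@]2(C)C3(C)C)nn1` gives 350 nM. The step of a 1.9-fold lower number from compound 1 to compound 2 (0.27 log units; within the scatter) and the step of a 1.4-fold lower number from compound 1 to compound 3 (0.15 log units; within the scatter) both replace the aryl group on the aromatic nitrogen, and neither moves the number beyond the scatter. Compound 4 `COc1ccc(-n2cc(CN3C(=O)C[C@@H]4CC[C@@]3(C)C4(C)C)nn2)cc1` differs from compound 1 by methoxy in place of cyano on an aromatic carbon, once more a change on that same aryl group. Given a 1.9-fold lower number from compound 1 to compound 2 (0.27 log units; within the scatter) and a 1.4-fold lower number from compound 1 to compound 3 (0.15 log units; within the scatter), no shift beyond the scatter is expected here either. The estimate for compound 4 is 400 nM, between 150 nM and 1100 nM, a step of a 1.3-fold lower number from compound 1 to compound 4 (0.10 log units; within the scatter) that is expected to remain within the scatter.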

Compound 4, half-maximal inhibitory concentration: 480 nM
Compound 4: the middle estimate sits 1.2-fold (0.08 log units) below what was measured, and the stated range covers the measured number.
By their numbers in this assay, from the lowest: compounds 2, 3, 4 and 1 (each within the scatter of the next).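

The change from 4-cyanophenyl to 4-methoxyphenyl leaves the number in place, a 1.0-fold lower number from compound 1 to compound 4 (0.02 log units; within the scatter), so a nitrile and a methoxy at this spot on the ring cannot be told apart here. The other two comparisons, a 1.4-fold higher number from compound 3 to compound 4 (0.14 log units; within the scatter) and a 1.8-fold higher number from compound 2 to compound 4 (0.25 log units; within the scatter), also stay within the scatter, so all four aryl groups shown read alike. Nothing measured here offers an explanation for this sameness. From the compounds shown here alone, whether an amine or a carboxylic acid on this ring would move the number beyond the scatter stays open.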